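The source may report more compounds than this note shows. Statements on the series, on what has been measured and on what is new or still open speak of the compounds shown alone.

Three related compounds have been measured in a functional assay on DU-145 cells (Homo sapiens) for antiproliferative activity, read by MTT assay, with a stated time of 48 h; a higher number here means a weaker inhibitor, a lower number a stronger inhibitor. Compound 1 `COc1ccccc1-n1cc(COC(=O)/C(C)=C/CC/C(C)=C/CC/C(C)=C/CC[C@@H]2[C@@]3(C)CCC(=O)C(C)(C)[C@H]3CC[C@@]2(C)O)nn1` carries a 2-methoxyphenyl group on an aromatic nitrogen, and in this assay compound 1 gives only a limit, > 150000 nM. Among the measured compounds shown here, compound 2 `COc1ccc(-n2cc(COC(=O)/C(C)=C/CC/C(C)=C/CC/C(C)=C/CC[C@@H]3[C@@]4(C)CCC(=O)C(C)(C)[C@H]4CC[C@@]3(C)O)nn2)cc1` differs by a 4-methoxyphenyl in place of the 2-methoxyphenyl on that nitrogen, and in this assay compound 2 gives 135000 nM, the only actual number among the three. That step is an at least 1.1-fold lower number from compound 1 to compound 2 (0.04 log units; that floor lies within the scatter). Compound 3 `C/C(=C\CC/C(C)=C/CC[C@@H]1[C@@]2(C)CCC(=O)C(C)(C)[C@H]2CC[C@@]1(C)O)CC/C=C(\C)C(=O)O` is the acid itself, without the attached group, and in this assay compound 3 again gives only a limit, > 150000 nM. So compound 2 stands alone with a number, while the other two sit at the limit of > 150000 nM in this assay, at which 2 of the 3 values shown sit.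

Compound 4 `C/C(=C\CC/C(C)=C/CC[C@@H]1[C@@]2(C)CCC(=O)C(C)(C)[C@H]2CC[C@@]1(C)O)CC/C=C(\C)C(=O)OCc1cn(-c2ccc(C(C)(C)C)cc2)nn1` is the compound still to be measured. It differs from compound 2 by tert-butyl in place of methoxy on an aromatic carbon. For the measured compounds named here, no measured step touches this group: the single step, from compound 1 to compound 2, exchanged one methoxyphenyl for another and stayed within the scatter. Going by the values given here, with no step bearing on the change and every value near the limit, no movement beyond the scatter is expected in this assay. Compound 4 is therefore expected to give about 140000 nM, between 70000 nM and 300000 nM. The expected step is a 1.0-fold higher number from compound 2 to compound 4 (0.02 log units; within the scatter), and a limit rather than a number is a real possibility.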

Compound 4, half-maximal inhibitory concentration: > 150000 nM
Compound 4 was reported as a limit (the forecaster's own chance of this, stated with the estimate: 55%); middle value at least 1.0-fold (0.02 log units) away from the limit.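

Putting tert-butyl in place of methoxy on the aromatic carbon para to a large group gives an at least 1.1-fold higher number from compound 2 to compound 4 (0.04 log units; that floor lies within the scatter). Going by these compounds, the value for compound 4 is a limit and not a number, so this step gives only a floor and its true size stays unknown; the steps between compounds that both sit at a limit cannot be read. This is the first look at a change at this place on the ring, and it adds no second actual number, so in this assay the only actual number remains that of compound 2, while the rest share one limit: the limit of > 150000 nM in this assay, at which 3 of the 4 values shown sit.

On these data alone, whether an amine or a carboxylic acid at this place on the ring would move the number beyond the scatter remains open. Also open, as far as these compounds go, is whether a longer chain on the aromatic nitrogen, in place of the whole substituted phenyl group, would give an actual number in this assay rather than a limit.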